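The source may report more compounds than this note shows. Statements on the series, on what has been measured and on what is new or still open speak of the compounds shown alone.

Compound 1 `O=C1NC(=S)/C(=C/c2cccc(Cl)c2)S1` and compound 2 `O=C1NC(=S)/C(=C/c2ccc(Br)cc2)S1` share one core and differ only in their aromatic halogen. In a functional assay on HEp-2 cells (Homo sapiens) for cytotoxicity, read by MTT assay, with a stated time of 72 h, tested at 1.25 ug/mL (on this read-out higher numbers stand for more inhibition of growth at the one concentration tested and lower numbers for less inhibition of growth), compound 1 gives -0.36%, and in this assay compound 2 gives -3.16%; the two numbers lie within the usual scatter of each other, so neither stands apart. Compound 3 `O=C1NC(=S)/C(=C/c2cccc(Br)c2)S1` is not yet measured. It differs from compound 1 by bromo in place of chloro on an aromatic carbon. For the measured compounds named here, with no measured step to lean on, the expected step of a number 0.6 percentage points lower from compound 1 to compound 3 (within the scatter) is none beyond the scatter. Compound 3 is therefore estimated at -1%, between -12% and 10%.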

Compound 3, percent growth inhibition at one concentration: -5.3%
Compound 3: middle estimate off by 4.3 percentage points, on the high side, and the stated range covers the measured number.
By their numbers in this assay, from the lowest: compounds 3, 2 and 1 (each within the scatter of the next).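

With bromo in place of chloro on an aromatic carbon, meta to a group of 8 heavy atoms, the step is a number 4.9 percentage points lower from compound 1 to compound 3 (within the scatter) in this assay. For the compounds shown here, this is the first single change at this position that can be read directly, and it does not separate the two halogens on this read-out. No evidence bears on the origin of this result. The compounds shown leave open how an amine or a carboxylic acid at this position would read in this assay. As far as these compounds go, whether any replacement here moves the number beyond the scatter also remains open.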